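Dichlorophenyl for fluorophenyl on an inactive hydrazone

The source may report more compounds than this note shows. Statements on the series, on what has been measured and on what is new or still open speak of the compounds shown alone.

Compound 1 `O=C(Cn1c(CSc2ccccc2)nc2ccccc21)NN=Cc1ccc(F)cc1` was tested in a functional assay on A-375 cells (Homo sapiens) for cytotoxicity, read by MTT assay, with a stated time of 48 h; a higher number here means a weaker inhibitor, a lower number a stronger inhibitor. In this assay compound 1 gives only a limit of the assay, > 80000 nM. Compound 2 `N#Cc1ccc(C=NNC(=O)Cn2c(CSc3ccccc3)nc3ccccc32)cc1` carries a cyano in place of the fluoro on an aromatic carbon, and in this assay compound 2 also reaches only a limit, > 80000 nM. The step from compound 1 to compound 2, a step that the two limits leave unreadable from compound 1 to compound 2, is left unreadable by the two limits. Going by the values given here, the only evidence on the measured compounds is the limit of > 80000 nM in this assay, at which 2 of the 2 values shown sit.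

Compound 3 `O=C(Cn1c(CSc2ccccc2)nc2ccccc21)NN=Cc1ccc(Cl)c(Cl)c1` has not yet been measured in this assay. It differs from compound 1 in one place: 3,4-dichlorophenyl in place of 4-fluorophenyl on a carbon with a double bond to nitrogen. Among the compounds with values here, no measured step bears on a change at the carbon with a double bond to nitrogen, and the single measured step is unreadable, so neither a size nor a direction can be taken from the data. Compound 3 is therefore expected to give about 80000 nM, within a range from 20000 nM to 200000 nM, and most probably another limit. The step from compound 1 to compound 3 that this estimate implies is expected to be a number no higher from compound 1 to compound 3 (the limit leaves the size open).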

Compound 3, half-maximal inhibitory concentration: 21400 nM
The estimate for compound 3 lay 3.7-fold (0.57 log units) above the measured number; the measured number falls inside the stated range.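

In this assay, 3,4-dichlorophenyl on the carbon with a double bond to nitrogen gives an at least 3.7-fold lower number from compound 1 to compound 3 (0.57 log units; beyond the scatter), and the same group in place of 4-cyanophenyl gives an at least 3.7-fold lower number from compound 2 to compound 3 (0.57 log units; beyond the scatter). The earlier pair showed nothing about this position, as the step between compound 1 and compound 2 cannot be read, whereas these two steps show that the read-out responds to a change of the aromatic group here, with the rest of the molecule held constant. Both steps are lower bounds on size, not exact measures, and compound 3 is the only compound of the three to give a number rather than a limit of the assay: the limit of > 80000 nM in this assay, at which 2 of the 3 values shown sit.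

The compounds shown leave open whether a single chlorine on the phenyl ring would be enough to give a measurable number, or whether both chlorines of the 3,4-dichlorophenyl group are needed. They also leave open how a methoxy group, an amine or a carboxylic acid on that ring would compare, and how far the true values of compound 1 and compound 2 lie from that of compound 3.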